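This account rests on a few compounds, and the source may have more. Where it says the series, first, only, none or still open, it means among the compounds named here.

In a physicochemical assay for solubility, read by turbidimetry, measured as kinetic solubility, at pH 7.4 (on this read-out higher numbers stand for higher solubility and lower numbers for lower solubility), compound 1 `CC1SC(c2cccc(C(=O)NCCCCc3ccccc3)c2)N(c2ccc(C3CC3)cc2)C1=O` gives 2000 nM, the lowest of the three numbers recorded. Compound 2 `C#Cc1cccc(N2C(=O)CSC2c2cccc(C(=O)NCCCCc3ccccc3)c2)c1` gives 10000 nM in this assay, and compound 3 `O=C(NCCCCc1ccccc1)c1cccc(C2SCC(=O)N2c2ccccc2F)c1` gives 10000 nM; both stand above compound 1 by more than the scatter, while the gap between compounds 2 and 3 themselves lies within it. Going by the values given here, the one step between compounds that differ in a single place, no change at the digits printed from compound 2 to compound 3 (within the scatter), concerns a 2-fluorophenyl in place of a 3-ethynylphenyl on the amide-type nitrogen in the ring, and it shows no change beyond the scatter.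

Compound 4 `O=C(NCCCCc1ccccc1)c1cccc(C2SCC(=O)N2c2ccc(C3CC3)cc2)c1` has not yet been measured. It differs from compound 1 by hydrogen in place of methyl on a saturated ring carbon. Among the compounds with values here, no measured step touches the saturated ring carbon, so the one step known gives no direct guide. With nothing in the data pointing to a large effect, the expected step is a 1.5-fold higher number from compound 1 to compound 4 (0.18 log units; within the scatter), within or only slightly beyond the scatter. Compound 4 is therefore estimated at 3000 nM, with a likely range from 1500 nM to 8000 nM.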

Compound 4, solubility: 2000 nM
Compound 4: the middle estimate sits 1.5-fold (0.18 log units) above what was measured; the measured number falls inside the stated range.
By their numbers in this assay, from the lowest: compounds 1 and 4 (each within the scatter of the next); then compounds 2 and 3 (each within the scatter of the next).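

In this assay, hydrogen in place of methyl on the saturated ring carbon next to the ring sulfur gives no change at the digits printed from compound 1 to compound 4 (within the scatter), so with 4-cyclopropylphenyl on the ring nitrogen, this position reads the same with either substituent. Going by these compounds alone, the gap to the earlier compounds can now be read at a single place, the group on the amide-type nitrogen: 4-cyclopropylphenyl in place of 2-fluorophenyl gives a 5.0-fold lower number from compound 3 to compound 4 (0.70 log units; beyond the scatter), and in place of 3-ethynylphenyl it gives a 5.0-fold lower number from compound 2 to compound 4 (0.70 log units; beyond the scatter). No measurement offered here explains these steps.

The compounds shown leave open whether the methyl would also leave the number unchanged with 2-fluorophenyl or 3-ethynylphenyl on the ring nitrogen. They also leave open how an ethyl group or an amine on the same saturated ring carbon would read.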